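The compounds below may be only part of what the source reports. "The series", "measured", "known", "first", "only" and "open" are said of these compounds alone.

In a functional assay on CHO cells for antagonist activity at 5-hydroxytryptamine receptor 6 (Homo sapiens), read by FLIPR (a lower number here means a stronger inhibitor, a higher number a weaker inhibitor), compound 1 `COc1ccc(S(=O)(=O)N2CC(C(=O)N(C)C3CCN(C)CC3)c3ccccc32)c2ccccc12` gives 7.94 nM. Compound 2 `COc1ccc(S(=O)(=O)N2CC(C(=O)N3CC(CN)C3)c3ccccc32)c2ccccc12` differs from it only in the group attached to the carbonyl carbon, and in this assay compound 2 gives 79.4 nM, the highest of the three numbers recorded so far. Compound 3 `COc1cccc(N2CCN(C(=O)C3CN(S(=O)(=O)c4ccc(OC)c5ccccc45)c4ccccc43)CC2)c1` gives 63.1 nM, which is within the scatter of compound 2. Going by the values given here, the single step that bears directly on the amide substituent is a 10-fold higher number from compound 1 to compound 2 (1.00 log units; beyond the scatter).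

The next compound, compound 4 `CCN(CC)CCCNC(=O)C1CN(S(=O)(=O)c2ccc(OC)c3ccccc23)c2ccccc21`, keeps the shared core and again alters only the group on the carbonyl carbon: (3-(diethylamino)propyl)amino in place of 3-(aminomethyl)azetidin-1-yl on a carbonyl carbon. Among the compounds with values here, no measured step goes from a four-membered ring at this position to an open chain, so the only guide is that exchanging one amide substituent for another in this assay moved the number from compound 1 to compound 2 by a modest but clear margin. A change of comparable size, in either direction, is therefore plausible, and the open chain carrying a tertiary amine has more in common with the substituent of compound 1 than with that of compound 2. On that basis compound 4 is expected to give about 25 nM, with a likely range from 8 nM to 80 nM, which corresponds to an expected step of a 3.2-fold lower number from compound 2 to compound 4 (0.50 log units; beyond the scatter).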

Compound 4, inhibition constant: 79.4 nM
Compound 4: middle estimate off by 3.2-fold (0.50 log units), on the low side, and the stated range covers the measured number.
By their numbers in this assay, from the lowest: compound 1; then compounds 3, 2 and 4 (each within the scatter of the next).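

Replacing the 3-(aminomethyl)azetidin-1-yl group with the open (3-(diethylamino)propyl)amino chain gives no change at the digits printed from compound 2 to compound 4 (within the scatter) in this assay, so at this carbonyl carbon, neither the loss of the four-membered ring nor the larger group has a readable effect on the number. The open chain also does not recover what the methyl(1-methylpiperidin-4-yl)amino group of compound 1 provides: the result is a 10-fold higher number from compound 1 to compound 4 (1.00 log units; beyond the scatter), the same size as a 10-fold higher number from compound 1 to compound 2 (1.00 log units; beyond the scatter), which leaves compound 1 alone at the low end among these amides. No measurement is available here to explain why compounds 2 and 4 match or why compound 1 stands apart.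

The step to compound 1 changes two features at once, the 1-methylpiperidin-4-yl ring and the methyl on the amide nitrogen, so the compounds shown cannot separate their contributions; a 1-methylpiperidin-4-ylamino group, which keeps the ring and has an amide hydrogen instead of that methyl, would address this. Going by these compounds, it also remains open whether a shorter or longer chain, or a pyrrolidine ring in place of the diethylamino end, would read differently from compound 4.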